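A few compounds are considered here, and "the series" means these few. Any claim that something is new, unique, unknown or untested is made for them only; others in the source may bear on it.

Compound 1 `COc1cc(OC)c2sc(-c3ccc(N/C=C\C(=O)c4cc(OC)c(OC)c(OC)c4)cc3)nc2c1`: 17800 nM
Compound 2 `COc1ccc(C(=O)/C=C\Nc2ccc(-c3nc4cc(OC)c(OC)c(OC)c4s3)cc2)cc1F`: 7300 nM
Compound 3 `COc1cc(C(=O)/C=C\Nc2ccc(-c3nc4cc(OC)c(OC)c(OC)c4s3)cc2C)cc(OC)c1OC`: 11100 nM

All three compounds were measured in a functional assay on HeLa cells (Homo sapiens) for antiproliferative activity, read by sulforhodamine B assay, with a stated time of 48 h; on this read-out higher numbers stand for weaker inhibition and lower numbers for stronger inhibition. Among the three numbers, compound 3 sits with compound 2 on one side and compound 1 on the other, and both gaps lie within the usual scatter of repeated measurements. Its number therefore cannot be clearly told apart from either neighbour.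

The next compound to consider is compound 4 `COc1cc(C(=O)/C=C\Nc2ccc(-c3nc4cc(OC)c(OC)c(OC)c4s3)cc2)cc(OC)c1OC`. It differs from compound 3 in one place only, with hydrogen in place of methyl on an aromatic carbon. That carbon belongs to a six-membered aromatic ring of carbon only, ortho to a large group and meta to a large group. For the measured compounds named here, a comparison of two compounds that differ in a single place is useful, but no measured pair here shows what this particular swap does on its own. The best available guide is compound 3 at 11100 nM, so no step beyond the scatter is expected in this assay, in either direction. The estimated step of a 1.1-fold lower number from compound 3 to compound 4 (0.05 log units; within the scatter) stays within that scatter. Compound 4 is estimated at 10000 nM, with an expected range of 3500 nM to 28000 nM.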

Compound 4, half-maximal inhibitory concentration: 5300 nM
Beside the measured number, compound 4's estimate is 1.9-fold (0.28 log units) above it; measured number inside the range.
By their numbers in this assay, from the lowest: compounds 4, 2, 3 and 1 (each within the scatter of the next, the first and the last beyond it).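

In this assay, for the compounds shown here, hydrogen in place of methyl on this aromatic carbon, ortho to a large group and meta to a large group, gives a 2.1-fold lower number from compound 3 to compound 4 (0.32 log units; beyond the scatter), a modest step, so this pair is the first to show that the position responds to a change. The core responds as well, since methoxy in place of hydrogen on an aromatic carbon gives a 3.4-fold lower number from compound 1 to compound 4 (0.53 log units; beyond the scatter), another modest step. By contrast, 3,4,5-trimethoxyphenyl in place of 3-fluoro-4-methoxyphenyl on a carbonyl carbon gives a 1.4-fold lower number from compound 2 to compound 4 (0.14 log units; within the scatter), which stays within the scatter, so these two groups cannot be told apart on this read-out. Nothing among the available findings explains why any of these steps has its size.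

At this position the comparison rests on a single pair, methyl against hydrogen, so it shows neither a trend nor how far it might extend. As far as these compounds go, whether an ethyl group, a chlorine atom or an amine on the same carbon would sit close to compound 3, close to compound 4 or elsewhere remains open.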